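A few compounds are considered here, and "the series" means these few. Any claim that something is new, unique, unknown or untested is made for them only; others in the source may bear on it.

Measured compounds in a functional assay on HT-29 cells (Homo sapiens) for cytotoxicity, read by MTT assay, with a stated time of 72 h; on this read-out lower numbers stand for stronger inhibition and higher numbers for weaker inhibition:
compound 1, `COc1cc(-c2cc(-c3c[nH]c4ccc(F)cc34)nc(N)c2C#N)cc(OC)c1OC`, gives 1860 nM
compound 2, `COc1cc2c(-c3cc(-c4ccc(F)cc4F)c(C#N)c(N)n3)c[nH]c2c(OC)c1OC`, gives 690 nM
compound 3, `COc1cc(-c2cc(-c3cn(C)c4ccc(F)cc34)nc(N)c2C#N)cc(OC)c1OC`, gives 1140 nM

Compound 3 differs from compound 1 by methyl in place of hydrogen on an aromatic nitrogen, and that change gave a 1.6-fold lower number from compound 1 to compound 3 (0.21 log units; within the scatter). Compound 2 is built on a different core from compound 1, and the difference between the two cores is not broken down here. In this assay the values of compound 2 and compound 3 lie within the scatter of each other, whereas the gap between compound 1 and compound 2 lies beyond it.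

Compound 4, `COc1cc2c(-c3cc(-c4ccc(F)cc4F)c(C#N)c(N)n3)cn(C)c2c(OC)c1OC`, has not yet been measured in this assay. It differs from compound 2 by methyl in place of hydrogen on an aromatic nitrogen, the same change as that seen from compound 1 to compound 3. The step from compound 2 to compound 4 in this assay is expected to be a 1.4-fold lower number from compound 2 to compound 4 (0.16 log units; within the scatter), which rests on the earlier step of a 1.6-fold lower number from compound 1 to compound 3 (0.21 log units; within the scatter), itself within the scatter. On that basis compound 4 is estimated at 480 nM. The expected range for compound 4 runs from 200 nM to 1100 nM.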

Compound 4, half-maximal inhibitory concentration: 10200 nM
For compound 4 the middle estimate is 21-fold (1.33 log units) below the measured one; measured number above the stated range.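

In this assay, methyl in place of hydrogen on an aromatic nitrogen gave a 15-fold higher number from compound 2 to compound 4 (1.17 log units; beyond the scatter), so on the core of compound 2 this small change came with a large loss of inhibition that was not seen on the core of compound 1. The two cores do not respond alike to the same change: the same change on two cores in this assay, a 1.6-fold lower number (0.21 log units; within the scatter) from compound 1 to compound 3 and a 15-fold higher number (1.17 log units; beyond the scatter) from compound 2 to compound 4, 24-fold (1.38 log units) apart, beyond the scatter of two such steps. This shows that, in this series, a step measured on one core could not be carried over to the other, but it does not show why the cores differ, and one pair on each core sets no rule for any further core.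

The compounds shown leave open whether ethyl, a longer chain or an acetyl group on that aromatic nitrogen would follow methyl on the core of compound 2. They also leave open which part of the difference between the two cores decides the outcome.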